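The compounds below may be only part of what the source reports. "The series", "measured", "known", "first", "only" and "open" are said of these compounds alone.

Measured so far, in an assay for inhibition of kynurenine 3-monooxygenase (Rattus norvegicus), tested at 10 uM; on this read-out lower numbers stand for less inhibition and higher numbers for more inhibition at the one concentration tested (going by the name of the read-out):
compound 1, `COC(=O)C(=N)/C=C(\O)c1ccc(Cl)cc1`, gives 13%;
compound 2, `COC(=O)C(=N)/C=C(\O)c1ccc(Cl)c(Cl)c1`, gives 37%;
compound 3, `N/C(=C\C(=O)c1ccccc1)C(=O)O`, gives 17%.

Compound 2 differs from compound 1 by chloro in place of hydrogen on an aromatic carbon, and this assay shows a number 24 percentage points higher from compound 1 to compound 2 (beyond the scatter). Compound 3 and compound 1 have different cores; the difference between the two cores is not broken down here. Compound 4, `N/C(=C\C(=O)c1ccc(Cl)cc1)C(=O)O`, has not yet been measured in this assay. It differs from compound 3 by chloro in place of hydrogen on an aromatic carbon. This is the same kind of change as from compound 1 to compound 2, but not the same: in compound 2 the chloro sits ortho to a chloro group and meta to a group of 9 heavy atoms, whereas in compound 4 it sits para to a group of 8 heavy atoms, on a different core. Because the earlier step was a number 24 percentage points higher from compound 1 to compound 2 (beyond the scatter), a rise is expected for compound 4 as well, but smaller, since the surroundings differ. The expected step is a number 13 percentage points higher from compound 3 to compound 4 (beyond the scatter). For compound 4 the estimate in this assay is 30%, between 12% and 50%.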

Compound 4, a percentage reported as inhibition, at one concentration (the size of the read-out at that concentration, not a potency): 33%
The estimate for compound 4 lay 3 percentage points below the measured number, and the stated range covers the measured number.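

In this assay, chloro in place of hydrogen on an aromatic carbon gives a number 16 percentage points higher from compound 3 to compound 4 (beyond the scatter), so the rise seen on the core of compound 1 also appears on a different core. The two steps can be read as similar in size: the same change on two cores in this assay, a number 24 percentage points higher (beyond the scatter) from compound 1 to compound 2 and a number 16 percentage points higher (beyond the scatter) from compound 3 to compound 4, 8 percentage points apart, within the scatter of two such steps. Among the compounds shown here, this rests on only two cores, however, the chloro stands in a different place on the ring in each step, and nothing here tells why the number rises.

The compounds shown leave open whether another group in that place, such as fluoro, methyl or methoxy, would also raise the number. They also leave open what a second chloro would do on the core of compound 3.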